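This account rests on a few compounds, and the source may have more. Where it says the series, first, only, none or still open, it means among the compounds named here.

Measured in a functional assay on SW480 cells (Homo sapiens) for antiproliferative activity, read by MTT assay, with a stated time of 48 h; on this read-out lower numbers stand for stronger inhibition and higher numbers for weaker inhibition:
- compound 1 `C=C1/C=C/C(=O)/C(CO)=C\C[C@](C)(CCC=C(C)C)/C=C/[C@H]1OC(=O)C=C(C)C`: 2970 nM
- compound 2 `CC(C)=CCC[C@]1(C)/C=C/[C@@H](OC(=O)C=C(C)C)[C@](C)(O)/C=C/C(=O)/C(CCl)=C\C1`: 390 nM

Of these two, compound 2 has the lower number at 390 nM, and the gap to compound 1 lies beyond the scatter. For the measured compounds named here, no two measured compounds differ in one place only, so no measured step speaks directly to the next change.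

Compound 3 `COCOC/C1=C/C[C@](C)(CCC=C(C)C)/C=C/[C@@H](OC(=O)C=C(C)C)[C@](C)(O)/C=C/C1=O` is still to be measured. It carries methoxymethoxy in place of chloro on a saturated chain carbon bound to a double-bonded ring carbon.

In this assay a step toward a higher number, beyond the scatter, is expected. Going by the values given here, the only guide is compound 1 at 2970 nM, the one measured compound with oxygen rather than chlorine on that carbon. It also differs from compound 2 elsewhere, so the guide is loose and the range is kept wide. The expected change is a 3.3-fold higher number from compound 2 to compound 3 (0.52 log units; beyond the scatter). For compound 3 the estimated value is 1300 nM, with an expected range from 400 nM to 4500 nM.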

Compound 3, half-maximal inhibitory concentration: 3710 nM
Compound 3: the middle estimate sits 2.9-fold (0.46 log units) below what was measured; low and high end bracket the measured number.
By their numbers in this assay, from the lowest: compound 2; then compounds 1 and 3 (each within the scatter of the next).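

In this assay the series now has its first single-place step (a 9.5-fold higher number from compound 2 to compound 3 (0.98 log units; beyond the scatter)), with methoxymethoxy in place of chloro on a saturated chain carbon bound to a double-bonded ring carbon. The number therefore responds to the group at this position while the rest of compound 2 stays fixed, which the earlier pair could not show because its two members also differ elsewhere. Nothing available explains the step, so it stands as an observation from a single pair.

This pair does not separate the loss of chloro from the entry of methoxymethoxy, so it remains unclear which of the two exchanges drives the higher number. Also open, on these data alone, is how other groups on the same carbon would read in this assay, for example bromo, an amine or an acetate ester, and whether the step would carry over to the core of compound 1.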